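Isopropoxy on the aromatic ring of compound 1

The source may report more compounds than this note shows. Statements on the series, on what has been measured and on what is new or still open speak of the compounds shown alone.

Going by the values given here, in an ADME assay on HEK293 cells (Homo sapiens) for cytotoxicity, read by MTT assay, with a stated time of 72 h (a lower number here means a stronger inhibitor, a higher number a weaker inhibitor), compound 1 `COc1ccc(C2=C(c3cc(OC)c(OC)c(OC)c3)C(=O)C(O)C2)cc1` gives 6.3 ug/mL, the only actual number so far. Compound 2 `COc1ccc(C2=C(c3cc(OC)c(OC)c(OC)c3)C(=O)C(O[SiH2]C(C)(C)C)C2)cc1` gives > 100 ug/mL, which is a limit of the assay. Among the compounds with values here, the one measured step, an at least 15-fold higher number from compound 1 to compound 2 (1.20 log units; beyond the scatter), is large and beyond the scatter, but it places a silicon-containing group on an oxygen on a saturated carbon. Compound 3 `COc1ccc(C2=C(c3cc(OC)c(OC)c(OC)c3)C(=O)C(O)C2)cc1OC(C)C` differs from compound 1 at another place: isopropoxy in place of hydrogen on an aromatic carbon. A smaller step in the same direction is expected, a 1.9-fold higher number from compound 1 to compound 3 (0.28 log units; within the scatter). For compound 3 the estimated value is 12 ug/mL, with an expected range of 3 ug/mL to 50 ug/mL.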

Compound 3, half-maximal inhibitory concentration: > 100 ug/mL
Compound 3 was reported as a limit; the forecaster's own chance of this, stated with the estimate: 10%; middle value at least 8.3-fold (0.92 log units) away from the limit.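

Isopropoxy in place of hydrogen on an aromatic carbon, ortho to a methoxy group, is the only change on an aromatic ring shown, and in this assay it gives an at least 15-fold higher number from compound 1 to compound 3 (1.20 log units; beyond the scatter). The number therefore responds beyond the scatter to this aromatic position, not only to substitution on the oxygen on a saturated carbon. The value of compound 3 is a limit, so this step is only a bound and its size cannot be set against the other step: the limit of > 100 ug/mL in this assay, at which 2 of the 3 values shown sit.

From the compounds shown here alone, whether a hydroxy group or an amine at this aromatic carbon stays within the scatter of compound 1 remains open. A methoxy group at the same carbon would also show how much of the oxygen-linked chain the position tolerates.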